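The compounds below may be only part of what the source reports. "The series", "measured", "known", "first", "only" and "open" are said of these compounds alone.

Compound 1 `CC(=O)O[C@H]1CC[C@]2(C)[C@H](CC[C@@](C)(O)[C@H]2CC[C@@H]2C(C)=CC[C@@H]3C(C)=CC[C@@H]3C2(C)C)OC1(C)C` gives 43500 nM
Compound 2 `CC1=CC[C@H]2[C@@H]1CC=C(C)[C@@H](CC[C@H]1[C@]3(C)CC[C@H](OC(=O)c4ccc(Cl)cc4)C(C)(C)O[C@H]3CC[C@@]1(C)O)C2(C)C` gives 22000 nM

Among the compounds with values here, these are the only two numbers available from a functional assay on MCF7 cells (Homo sapiens) for antiproliferative activity, read by MTT assay, with a stated time of 72 h (a higher number here means a weaker inhibitor, a lower number a stronger inhibitor), so far. Compound 2 at 22000 nM lies within the scatter of compound 1, so the two cannot be ranked. Compound 3 `CC1=CC[C@H]2[C@@H]1CC=C(C)[C@@H](CC[C@H]1[C@]3(C)CC[C@H](OCc4ccccc4)C(C)(C)O[C@H]3CC[C@@]1(C)O)C2(C)C` differs from compound 2 in one place. The change reads benzyl in place of (4-chlorophenyl)carbonyl on an oxygen on a saturated carbon or in words benzyl in place of (4-chlorophenyl)carbonyl on an oxygen on a saturated carbon. Within the data shown here, the only measured step that bears on this is a 2.0-fold lower number from compound 1 to compound 2 (0.30 log units; within the scatter) which replaced the group on a carbonyl carbon and stayed within the scatter. Among the measured compounds shown here, no measured compound lacks that carbonyl, so this evidence is indirect and the range must be wide. The expected change is a 1.1-fold higher number from compound 2 to compound 3 (0.06 log units; within the scatter) and no step beyond the scatter is expected. Compound 3 is estimated at 25000 nM with a range of 9000 nM to 65000 nM expected.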

Compound 3, half-maximal inhibitory concentration: > 50000 nM
Compound 3 ended at the assay's limit (the forecaster's own chance of this, stated with the estimate: 15%); at least 2.0-fold (0.30 log units) between middle value and limit.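

In this assay compound 3 gives > 50000 nM, which is a limit of the assay and not a number. Even so, this oxygen-bearing position now shows a response: replacing (4-chlorophenyl)carbonyl with benzyl gives an at least 2.2-fold higher number from compound 2 to compound 3 (0.35 log units; beyond the scatter), whereas the earlier change, which kept the carbonyl, stayed within the scatter. Replacing acetyl with benzyl gives an at least 1.1-fold higher number from compound 1 to compound 3 (0.06 log units; that floor lies within the scatter), so that floor does not separate compound 3 from compound 1.

The change from compound 2 to compound 3 removes the carbonyl and the chlorine together, so a plain benzoyl group, which keeps the carbonyl without the chlorine, would be needed to tell which of the two matters. The true size of the step also stays open: the limit of > 50000 nM in this assay, at which 1 of the 3 values shown sits.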